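Taking one benzyl group off compound 3

This account rests on a few compounds, and the source may have more. Where it says the series, first, only, none or still open, it means among the compounds named here.

In a functional assay on I10 cells (Mus musculus) for inhibition, read by MTT assay, with a stated time of 72 h (a lower number here means a stronger inhibitor, a higher number a weaker inhibitor), compound 3 `C=CCc1ccc(OCc2ccc(Cl)c(Cl)c2)c(-c2ccc(OCc3ccc(Cl)c(Cl)c3)c(CC=C)c2)c1` gives > 50000 nM as a limit of the assay, not a number. Compound 3 therefore stands at the limit of > 50000 nM in this assay, at which 1 of the 3 values shown sits, on this scale. Compound 1 `C=CCc1ccc(OCc2ccc(Cl)cc2Cl)c(-c2ccc(O)c(CC=C)c2)c1` gives 21100 nM and compound 2 `C=CCc1ccc(O)c(-c2ccc(OCc3ccc(Cl)c(Cl)c3)c(CC=C)c2)c1` gives 12300 nM in this assay and each of these two keeps one free hydroxy group.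

The change to compound 4 `C=CCc1ccc(OCc2ccc(Cl)c(Cl)c2)c(-c2ccc(O)c(CC=C)c2)c1` is hydrogen in place of 3,4-dichlorobenzyl on an oxygen on an aromatic ring and it puts hydrogen in place of 3,4-dichlorobenzyl on an oxygen on an aromatic ring. For the measured compounds named here, one measured step bears on this, namely an at least 4.0-fold higher number from compound 2 to compound 3 (0.60 log units; beyond the scatter) for adding that same group, though on a different oxygen. Read backwards, that step suggests that losing the group should lower the number clearly, by an amount left open at compound 3 by its limit. The expected size is an at least 3.3-fold lower number from compound 3 to compound 4 (0.52 log units; beyond the scatter) in the direction of stronger inhibition. Compound 4 is estimated at 15000 nM with an expected range from 7000 nM to 32000 nM.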

Compound 4, half-maximal inhibitory concentration: 12200 nM
Compound 4: middle estimate off by 1.2-fold (0.09 log units), on the high side; the measured number falls inside the stated range.
By their numbers in this assay, from the lowest: compounds 4, 2 and 1 (each within the scatter of the next). At a limit, above all of these: compound 3.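

In this assay, taking the 3,4-dichlorobenzyl group off this oxygen on an aromatic ring gives an at least 4.0-fold lower number from compound 3 to compound 4 (0.61 log units; beyond the scatter), so the change towards stronger inhibition seen earlier on the other oxygen also appears at this position. The chlorine pattern on the benzyl group held on this oxygen shows no clear effect, with 3,4-dichlorophenyl in place of 2,4-dichlorophenyl giving a 1.7-fold lower number from compound 1 to compound 4 (0.24 log units; within the scatter). Compound 3 has a limit and not a number, so the true size of the first step remains unknown: the limit of > 50000 nM in this assay, at which 1 of the 4 values shown sits.

The compounds shown leave open how a compound with hydrogen on both oxygens would behave. They also leave open whether a small methyl group on this oxygen, or an amine in place of the hydroxy group, would change the number.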